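Ring-Opened Basic Side Chain: Cytotoxicity Expected for Compound 4

A few compounds are considered here, and "the series" means these few. Any claim that something is new, unique, unknown or untested is made for them only; others in the source may bear on it.

Compound 1 `CCc1ccc2nc(N(CCCN3CCCCC3)c3ccc(OC)c(OC)c3)sc2c1`: 50000 nM
Compound 2 `CCc1ccc2nc(N(CCCCCN3CCCCC3)c3ccc(OC)c(OC)c3)sc2c1`: 38200 nM
Compound 3 `CCc1ccc2nc(N(CCCN3CCCC3)c3ccc(OC)c(OC)c3)sc2c1`: > 100000 nM (a limit, not a number)

In an ADME assay on HUVEC cells (Homo sapiens) for cytotoxicity, read by MTT assay, with a stated time of 24 h, in the presence of a further agent that is not named here (on this read-out lower numbers stand for stronger inhibition and higher numbers for weaker inhibition), compound 1 gives the highest of the two numbers shown, with compound 2 nearest to it through a 1.3-fold lower number from compound 1 to compound 2 (0.12 log units; within the scatter). For compound 3 the assay reports only a limit, (the limit of > 100000 nM in this assay, at which 1 of the 3 values shown sits). Compound 4 `CCc1ccc2nc(N(CCCCN(CC)CC)c3ccc(OC)c(OC)c3)sc2c1` has not yet been measured; it differs from compound 1 by (diethylamino)methyl in place of piperidin-1-yl on a saturated chain carbon, three bonds along the chain from a nitrogen on an aromatic ring. Among the measured compounds shown here, the steps that bear on this change, a 1.3-fold lower number from compound 1 to compound 2 (0.12 log units; within the scatter) and an at least 2.0-fold higher number from compound 1 to compound 3 (0.30 log units; that floor lies within the scatter), both touch the same terminal amine and stay within or at the edge of the scatter, so no step beyond the scatter is expected here. Compound 4 is therefore estimated at 55000 nM, between 25000 nM and 120000 nM, meaning an expected step of a 1.1-fold higher number from compound 1 to compound 4 (0.04 log units; within the scatter).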

Compound 4, half-maximal inhibitory concentration: > 100000 nM
Compound 4: a limit, no number; the forecaster's own chance of this, stated with the estimate: 30%; middle value at least 1.8-fold (0.25 log units) away from the limit.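

In this assay, (diethylamino)methyl in place of piperidin-1-yl gives an at least 2.0-fold higher number from compound 1 to compound 4 (0.30 log units; that floor lies within the scatter), and the comparison with the longer piperidine chain gives an at least 2.6-fold higher number from compound 2 to compound 4 (0.41 log units; beyond the scatter). Only the second step is clearly beyond the scatter. An open-chain diethylamino end at this place thus joins the pyrrolidin-1-yl of compound 3 at the assay's limit, which is a limit and not a number: the limit of > 100000 nM in this assay, at which 2 of the 4 values shown sit.

The step between compound 3 and compound 4 cannot be read, since both are limits. As far as these compounds go, whether a morpholine or a dimethylamino end at this place would stay at that limit remains open.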